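A few compounds are considered here, and "the series" means these few. Any claim that something is new, unique, unknown or untested is made for them only; others in the source may bear on it.

Compound 1 `Cc1c[nH]c2c(NC(N[C@H]3CCCCN(CC(=O)N4CCCC4)C3=O)=C(C#N)C#N)cccc12` and compound 2 `N#CC(C#N)=C(Nc1cccc2c(Cl)c[nH]c12)N[C@H]1CCCCN(CC(=O)N2CCCC2)C1=O` are identical except in one spot: chloro in place of methyl on an aromatic carbon. In an ADME assay on a cell-free system (serum, Homo sapiens) for protein binding, using equilibrium dialysis, with a stated time of 4 h, tested at 10 uM, compound 1 gives 77%, while compound 2 gives 88%; the step between them is a 1.9-fold lower unbound fraction from compound 1 to compound 2 (0.28 log units; within the scatter). Compound 3 `Cc1c[nH]c2c(N/C(=C\C#N)N[C@H]3CCCCN(CC(=O)N4CCCC4)C3=O)cccc12` carries the same methyl-bearing core as compound 1 but a different link to the rest of the molecule; how its core differs from that of compound 1 is not broken down here. In this assay compound 3 gives 80%, a value that sits close to that of compound 1.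

Compound 4 `N#C/C=C(\Nc1cccc2c(Cl)c[nH]c12)N[C@H]1CCCCN(CC(=O)N2CCCC2)C1=O` has not yet been measured. It stands to compound 3 exactly as compound 2 stands to compound 1, the same change made at the same place: chloro in place of methyl on an aromatic carbon. Because the matching change gave a 1.9-fold lower unbound fraction from compound 1 to compound 2 (0.28 log units; within the scatter), a step of similar size is expected here, namely a 1.8-fold lower unbound fraction from compound 3 to compound 4 (0.26 log units; within the scatter). Compound 4 is therefore estimated to show 89%, most likely falling between 82% and 95%.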

Compound 4, plasma protein binding: 84%
Compound 4: the middle estimate sits 1.5-fold (0.16 log units) (unbound fraction) below what was measured, within the range that was stated.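

The new step, read in this assay, is a 1.3-fold lower unbound fraction from compound 3 to compound 4 (0.10 log units; within the scatter). Set beside the earlier step, it gives no sign that the swap of methyl for chloro depends on the core: the same change on two cores in this assay, a 1.9-fold lower unbound fraction (0.28 log units; within the scatter) from compound 1 to compound 2 and a 1.3-fold lower unbound fraction (0.10 log units; within the scatter) from compound 3 to compound 4, 1.5-fold (0.19 log units) apart, within the scatter of two such steps. Among these compounds, this shows only that the two steps cannot be told apart on these two cores; each step lies within the scatter by itself, so the data neither establish that the swap truly alters binding to serum protein nor predict what it would do on any other core.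

Among the compounds shown, only methyl and chloro occupy this aromatic carbon, so it remains open how a fluoro, a methoxy or an amine would behave there. The part of the molecule on the far side of the link is the same in all four compounds, which leaves open whether the swap would give a similar step with a carboxylic acid placed on that part.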